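From dimethylamino to fluoro on the shared core

The source may report more compounds than this note shows. Statements on the series, on what has been measured and on what is new or still open speak of the compounds shown alone.

In an ADME assay on microsomes from liver (Homo sapiens) for metabolic stability, read by LC-MS, using NADPH, with a stated time of 60 min, tested at 10 uM (a lower number here means that less of the compound is left, a higher number that more of the compound is left), compound 1 `CCc1ccc(N(CC(C)C)S(=O)(=O)c2ccc3c(c2)C(=O)CC(C2CCOCC2)O3)cc1` gives 3.2% and compound 2 `CC(C)CN(c1ccc(N(C)C)cc1)S(=O)(=O)c1ccc2c(c1)C(=O)CC(C1CCOCC1)O2` gives 11.5% as its number. Going by the values given here, these two values lie within the scatter of each other, so compound 2 cannot be ranked against compound 1, the only other measured compound.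

Compound 3 `CC(C)CN(c1ccc(F)cc1)S(=O)(=O)c1ccc2c(c1)C(=O)CC(C1CCOCC1)O2` is still to be measured and carries fluoro in place of dimethylamino on an aromatic carbon, para to a large group (fluoro in place of dimethylamino on an aromatic carbon). Among the compounds with values here, the one measured step at this place, dimethylamino in place of ethyl, is a number 8.3 percentage points higher from compound 1 to compound 2 (within the scatter) and no measured compound carries fluoro, so the data give no ground for a larger step here.

No step beyond the scatter is expected in this assay in either direction, the estimated step being a number 2.5 percentage points lower from compound 2 to compound 3 (within the scatter) on this reading. Compound 3 is expected at 9% with 2% to 25% as the estimated range.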

Compound 3, percent of the compound remaining: 0.2%
Estimate against measurement, compound 3: 8.8 percentage points above, and the stated range ends above it.
By their numbers in this assay, from the lowest: compounds 3, 1 and 2 (each within the scatter of the next, the first and the last beyond it).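

Going by these compounds alone, at this position, para to a large group, this assay now separates two substituents for the first time: fluoro in place of dimethylamino gives (a number 11.3 percentage points lower from compound 2 to compound 3 (beyond the scatter)). Fluoro in place of ethyl gives (a number 3 percentage points lower from compound 1 to compound 3 (within the scatter)), so compound 1 and compound 3 cannot be ranked against each other, and the difference rests on the single pair compound 2 and compound 3. No measurement on hand bears on why this step occurs.

On these data alone, whether an amine other than dimethylamino, such as a morpholine, would keep or widen the step remains open, as does the outcome with methoxy or a carboxylic acid at the same place. As far as these compounds go, it is also open whether the step at this position would hold if the shared core were changed elsewhere.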